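Trimming the side chain on a weakly active coumarin

The source may hold more compounds than are shown below. What is called first, only, known or untested is meant among the compounds shown, and "the series" means these compounds.

Compound 1, `C[C@H](Nc1cc(=O)oc2cc(OCc3ccccc3)ccc12)C(N)=O`, is measured in an assay (strain Wistar) for inhibition of Amine oxidase [flavin-containing] A (Rattus norvegicus) (on this read-out lower numbers stand for stronger inhibition and higher numbers for weaker inhibition), where compound 1 gives 100000 nM. That is the highest of the two numbers at hand, so compound 1 is the weakest inhibitor among the measured compounds. The nearest measured value belongs to compound 3, `NC(=O)Cc1cc(=O)oc2cc(OCc3cccc(O)c3)ccc12`, which in this assay gives 4270 nM, a gap well beyond the usual scatter. Compound 2, `NC(=O)[C@H](CO)Nc1cc(=O)oc2cc(OCc3cccc(Cl)c3)ccc12`, gives only a limit in this assay, > 100000 nM, which is the point at which one of the three values sits: the limit of > 100000 nM in this assay, at which 1 of the 3 values shown sits.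

The unmeasured compound 4, `NCc1cc(=O)oc2cc(OCc3ccccc3)ccc12`, differs from compound 1 in a single place: aminomethyl in place of (1-carbamoylethyl)amino on an aromatic carbon. Among the measured compounds shown here, no pair of measured compounds shows exactly this change, so the size of the step from compound 1 to compound 4 cannot be read from the data. Since the smaller aminomethyl group keeps one hydrogen-bond donor and one acceptor, the number for compound 4 is expected to move modestly downward, as a 3.3-fold lower number from compound 1 to compound 4 (0.52 log units; beyond the scatter). Compound 4 is estimated at 30000 nM, within a range from 5000 nM to 150000 nM.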

Compound 4, half-maximal inhibitory concentration: 4400 nM
The estimate for compound 4 lay 6.8-fold (0.83 log units) above the measured number; measured number outside the range, below it.
By their numbers in this assay, from the lowest: compounds 3 and 4 (each within the scatter of the next); then compound 1.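

In this assay, exchanging (1-carbamoylethyl)amino for aminomethyl on the core gives a 23-fold lower number from compound 1 to compound 4 (1.36 log units; beyond the scatter), so what sits at this position, opposite the ring oxygen, clearly matters for inhibition. The group that leaves carries a defined stereocentre and a double bond, and neither is required for activity on this scale, since compound 4 has neither and gives 4400 nM in this comparison. Among the compounds shown here, this is the only step here between compounds that differ in one place, and nothing measured explains why it is so large.

On these data alone, how a primary amine set directly on the core, an aminoethyl chain or a carboxylic acid would compare at this position stays open. Also open, as far as these compounds go, is whether the step keeps its size when the benzyl group carries a chlorine or a hydroxyl.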